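Clearance step from compound 3 to compound 4

A few compounds are considered here, and "the series" means these few. Any claim that something is new, unique, unknown or untested is made for them only; others in the source may bear on it.

In an ADME assay (liver) for metabolic stability, with Liver microsome (Rattus norvegicus) as the target, using microsomes and NADPH, with a stated time of 30 min (a lower number here means slower removal, a higher number faster removal of the compound), compound 1 (`CC#C[C@H]1CN(S(=O)(=O)c2ccc(N)nc2)CCN1c1ncc(C(C)(O)C(F)(F)F)s1`) gives 87 mL.min-1.g-1, compound 2 (`CC#C[C@H]1CN(S(=O)(=O)c2ccc(N)nc2)CCN1c1ccc(S(=O)(=NC)C(F)(F)F)cc1`) gives 257 mL.min-1.g-1 and compound 3 (`CC#C[C@H]1CN(S(=O)(=O)c2ccc(N)nc2)CCN1c1ccc(S(=O)(=O)NCC2CC2)cc1`) gives 213 mL.min-1.g-1. Compound 3 lies within the scatter of compound 2, and its number is higher than that of compound 1. Compound 4 (`CC#C[C@H]1CN(S(=O)(=O)c2ccc(N)nc2)CCN1c1ccc(S(=N)(=O)C2CC2)cc1`) loses the (cyclopropylmethyl)sulfamoyl of compound 3, on an aromatic carbon para to a large group: a group of 6 heavy atoms (3 carbon, 1 nitrogen, 1 oxygen, 1 sulfur; one three-membered non-aromatic ring of carbon only) in place of a group of 8 heavy atoms (4 carbon, 1 nitrogen, 2 oxygen, 1 sulfur; one three-membered non-aromatic ring of carbon only), on an aromatic carbon. Among the measured compounds shown here, the only measured step at this place is a 1.2-fold lower number from compound 2 to compound 3 (0.08 log units; within the scatter), and it involves a different exchange, so it is a loose guide. No step beyond the scatter is expected in this assay. The estimated step is a 1.3-fold lower number from compound 3 to compound 4 (0.10 log units; within the scatter). For compound 4 the expected value is 170 mL.min-1.g-1, with an estimated range of 90 mL.min-1.g-1 to 320 mL.min-1.g-1.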

Compound 4, intrinsic clearance in microsomes: 23 mL.min-1.g-1
For compound 4 the middle estimate is 7.4-fold (0.87 log units) above the measured one, and the stated range ends above it.
By their numbers in this assay, from the lowest: compound 4; then compound 1; then compounds 3 and 2 (each within the scatter of the next).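

The aromatic carbon para to a large group is sensitive to the exchange in this assay: the measured change is a 9.3-fold lower number from compound 3 to compound 4 (0.97 log units; beyond the scatter) and, from the other side, an 11-fold lower number from compound 2 to compound 4 (1.05 log units; beyond the scatter). Compound 2 and compound 3 had shown no such separation, with a 1.2-fold lower number from compound 2 to compound 3 (0.08 log units; within the scatter), so the entering group sets compound 4 apart from both. The data shown give no explanation for this difference.

Still open, on these data alone, is whether a methyl or ethyl chain in place of the three-membered ring of the entering group would keep the number near that of compound 4.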